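Estimating Rat Clearance After a Side-Chain Exchange

The compounds below may be only part of what the source reports. "The series", "measured", "known", "first", "only" and "open" are said of these compounds alone.

Two related compounds have been followed in an ADME assay on the whole organism (Rattus norvegicus) for pharmacokinetics, at a dose of 1 mg/kg by the intravenous route; on this read-out lower numbers stand for slow clearance and higher numbers for fast clearance. There, compound 1 (`Cc1c(-c2ccc3c(c2)OCCO3)cccc1C(F)(F)Oc1cc(OCc2cncc(C#N)c2)c(CNC(CO)(CO)CO)cc1Cl`) gives 89 mL/min/kg and compound 2 (`Cc1c(-c2ccc3c(c2)OCCO3)cccc1C(F)(F)Oc1cc(OCc2ccnc(C#N)c2)c(CN2CCCC[C@H]2C(=O)O)cc1Cl`) gives 143 mL/min/kg. These two numbers lie within the usual scatter of each other, so the data do not separate compound 2 from compound 1.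

Compound 3 (`Cc1c(-c2ccc3c(c2)OCCO3)cccc1C(F)(F)Oc1cc(OCc2ccnc(C#N)c2)c(CN[C@@H]2C(O)O[C@H](CO)[C@@H](O)[C@@H]2O)cc1Cl`) has not yet been measured. It departs from compound 2 on a saturated chain carbon bound to an aromatic carbon: a group of 12 heavy atoms (6 carbon, 1 nitrogen, 5 oxygen; one six-membered non-aromatic ring with 1 hetero atom) in place of a group of 9 heavy atoms (6 carbon, 1 nitrogen, 2 oxygen; one six-membered non-aromatic ring with 1 hetero atom), on a saturated chain carbon bound to an aromatic carbon. Among the measured compounds shown here, no measured pair shows what this exchange does, which leaves only a weak guide. With a side chain different from that of compound 2, compound 1 still gives 89 mL/min/kg. On that basis, the expected change in this assay is a small one toward lower numbers, with nothing beyond the scatter. The expected step is a 1.4-fold lower number from compound 2 to compound 3 (0.13 log units; within the scatter). For compound 3 the estimated clearance is 105 mL/min/kg, with an expected range of 55 mL/min/kg to 190 mL/min/kg.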

Compound 3, clearance: 40 mL/min/kg
Compound 3: middle estimate off by 2.6-fold (0.42 log units), on the high side, and the stated range ends above it.
By their numbers in this assay, from the lowest: compound 3; then compounds 1 and 2 (each within the scatter of the next).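

In this assay, among the compounds shown here, the place on a saturated chain carbon bound to an aromatic carbon proves able to move the read-out: with only this group exchanged, 2-carboxypiperidin-1-yl giving way to the group of 12 heavy atoms yields a 3.6-fold lower number from compound 2 to compound 3 (0.55 log units; beyond the scatter) and so goes beyond the scatter. The earlier compounds shown here could not show this, since compound 1 and compound 2 differ in more than one place and their numbers lie within the scatter of each other. The exchange also alters several things at once, including the loss of the carboxylic acid and the arrival of further hydroxyl groups on the ring, and no measurement here explains the size of the step or assigns it to any one of those features.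

For the compounds shown here, the single step therefore leaves open whether the ring oxygen, the hydroxyl groups or the missing carboxylic acid matters most for clearance at this place. A plain piperidin-1-yl group, or a morpholin-4-yl group, at the same place would help to separate these features, and how either would behave in this assay remains unknown from the compounds shown.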